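Isopropylamino in Place of Diisobutylamino on the Shared Core

The source may hold more compounds than are shown below. What is called first, only, known or untested is meant among the compounds shown, and "the series" means these compounds.

Measured compounds:
compound 1 `CC(C)N(CC(C1CCCCC1)N1CCN(C(=O)[C@@H]2CN(C(C)(C)C)C[C@H]2c2ccc(F)cc2F)CC1)C(=O)c1ncccn1` gives 15 nM; 10 nM (2 entries)
compound 2 `CC(C)CN(CC(C)C)CC(C1CCCCC1)N1CCN(C(=O)[C@@H]2CN(C(C)(C)C)C[C@H]2c2ccc(F)cc2F)CC1` gives 6700 nM
compound 3 `CC(C)N(CC(C1CCCCC1)N1CCN(C(=O)[C@@H]2CN(C(C)(C)C)C[C@H]2c2ccc(F)cc2F)CC1)C(=O)c1cccnn1` gives 9.1 nM; 5.4 nM (2 entries)

All three compounds share the same core and were tested in a functional assay on CHO cells for agonist activity at Melanocortin receptor 4 (Homo sapiens), read by cAMP accumulation; a lower number here means that less compound is needed, a higher number that more compound is needed for the effect. Compound 1 and compound 3 carry an acylated nitrogen on the side chain and each gives repeated entries close together, as seen in the several entries of compound 1 in this assay, 15 nM; 10 nM (2 entries) and (the several entries of compound 3 in this assay, 9.1 nM; 5.4 nM (2 entries)). For the measured compounds named here, compound 2, with a diisobutylamino group in that position, stands far weaker than either and is the only member of the set for which a single number is given, with two further entries in this assay that yielded no single number.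

Compound 4 `CC(C)NCC(C1CCCCC1)N1CCN(C(=O)[C@@H]2CN(C(C)(C)C)C[C@H]2c2ccc(F)cc2F)CC1` has not yet been measured. It differs from compound 2 by isopropylamino in place of diisobutylamino on a saturated chain carbon, two bonds along the chain from an amine nitrogen in a ring and a saturated ring carbon. Going by the values given here, no step between measured compounds matches this change, so the expected size rests on the spread between the acylated compounds and compound 2 alone. The smaller secondary amine is expected to move compound 4 somewhat toward the acylated compounds, the step of a 4.5-fold lower number from compound 2 to compound 4 (0.65 log units; beyond the scatter) being estimated as a modest gain beyond the scatter but not closing the gap.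

Compound 4 is therefore expected to give about 1500 nM in this assay, within a range of 200 nM to 10000 nM.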

Compound 4, half-maximal effective concentration: 240 nM
Compound 4: the middle estimate sits 6.3-fold (0.80 log units) above what was measured, within the range that was stated.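

In this assay, exchanging diisobutylamino for isopropylamino on this saturated chain carbon gives a 28-fold lower number from compound 2 to compound 4 (1.45 log units; beyond the scatter), which shows that a large part of the distance between compound 2 and the acylated compounds can be covered at this position without any acyl group. The change in compound 4 also replaces a group of 9 heavy atoms and 0 hydrogen-bond donors with one of 4 heavy atoms and 1 hydrogen-bond donor, so these are the differences tied to the step. Even so, compound 4 at 240 nM keeps a higher number than its acylated counterpart, compound 1, so placing an acyl group on the isopropylamino nitrogen goes with a further gain: the several entries of compound 1 in this assay, 15 nM; 10 nM (2 entries)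

The compounds shown leave open whether the heavy-atom count or the hydrogen-bond donor matters more for this step, and a dimethylamino group in the same place, which has no hydrogen-bond donor, would help to separate the two. How a simple acetyl group on the isopropylamino nitrogen would compare with the entries of compound 3 also stays open: the several entries of compound 3 in this assay, 9.1 nM; 5.4 nM (2 entries)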